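This account rests on a few compounds, and the source may have more. Where it says the series, first, only, none or still open, it means among the compounds named here.

Compound 3 `Cc1nc(N)c2c(-c3cc4ccccc4o3)cn([C@@H]3O[C@H](CO)[C@@H](O)[C@H]3O)c2n1` is tested in an ADME assay on MRC5 cells (Homo sapiens), read by MTT assay, with a stated time of 72 h (on this read-out higher numbers stand for weaker inhibition and lower numbers for stronger inhibition), where compound 3 gives 91800 nM; compound 1 `Nc1nc(N)c2c(-c3cc4ccccc4o3)cn([C@@H]3O[C@H](CO)[C@@H](O)[C@H]3O)c2n1` gives 78500 nM, and of these two numbers compound 3 carries the larger figure, although a 1.2-fold higher number from compound 1 to compound 3 (0.07 log units; within the scatter). Compound 2 `Nc1nc(N)c2c(-c3ccoc3)cn([C@@H]3O[C@H](CO)[C@@H](O)[C@H]3O)c2n1` reaches only a limit of this assay, > 100000 nM. Compound 4 `Cc1nc(N)c2c(-c3ccccc3)cn([C@@H]3O[C@H](CO)[C@@H](O)[C@H]3O)c2n1` arises from compound 3 by one change: phenyl in place of 1-benzofuran-2-yl on an aromatic carbon. Among the compounds with values here, the single measured step at the same aromatic carbon is an at least 1.2-fold higher number from compound 1 to compound 2 (0.10 log units; that floor lies within the scatter), where compound 2 sits at the limit of > 100000 nM in this assay, at which 1 of the 3 values shown sits. That step shows no movement beyond the scatter, so the expected step of a 1.1-fold higher number from compound 3 to compound 4 (0.04 log units; within the scatter) is small. Compound 4 is therefore estimated at 100000 nM in this assay, within the range 50000 nM to 200000 nM, with a fair chance that only a limit is reported.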

Compound 4, half-maximal inhibitory concentration: > 100000 nM
Compound 4: a limit, no number; the forecaster's own chance of this, stated with the estimate: 45%; the middle value sits exactly at the limit.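

Putting phenyl in place of 1-benzofuran-2-yl on this aromatic carbon, with methyl rather than amino on the core, gives an at least 1.0-fold higher number from compound 3 to compound 4 (0.03 log units; that floor lies within the scatter). Within the data shown here, compound 4 gives only a limit, so the real size of this step is unknown, but a second version of the core now also shows no step at this carbon beyond the scatter. Limits now take up a larger share of the data: the limit of > 100000 nM in this assay, at which 2 of the 4 values shown sit.

Going by these compounds, whether an amine, a carboxylic acid or a longer chain on this carbon would give a number clearly lower in this assay stays open.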